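The source may report more compounds than this note shows. Statements on the series, on what has been measured and on what is new or still open speak of the compounds shown alone.

In a functional assay on HEK293 cells for agonist activity at G-protein coupled receptor 39 (Homo sapiens), read by scintillation proximity assay and inositol phosphate accumulation, with a stated time of 75 min, in the presence of a further agent that is not named here (a lower number here means that less compound is needed, a higher number that more compound is needed for the effect), compound 3 `Cc1nn(-c2ncnc3nc[nH]c23)c2c1C(NC(=O)Cc1cccs1)CC(=O)N2` gives 3 nM, level with compound 1 `Cc1nn(-c2ncnc3nc[nH]c23)c2c1C(OCC(=O)c1ccc(F)cc1)CC(=O)N2`, which gives 3 nM; together these are the lowest of the three numbers, while compound 2 `Cc1nn(-c2ncnc3nc[nH]c23)c2c1C(C(=O)N(C)c1nccs1)CC(=O)N2` gives 18 nM. Among the compounds with values here, the one step measured at this position, a 6.0-fold lower number from compound 2 to compound 3 (0.78 log units; beyond the scatter), is modest. Compound 4 `Cc1nn(-c2ncnc3nc[nH]c23)c2c1C(OCCn1nccc1C)CC(=O)N2` differs from compound 3 at the same place: a group of 9 heavy atoms (6 carbon, 2 nitrogen, 1 oxygen; one five-membered aromatic ring with 2 hetero atoms) in place of a group of 9 heavy atoms (6 carbon, 1 nitrogen, 1 oxygen, 1 sulfur; one five-membered aromatic ring with 1 hetero atom), on a saturated ring carbon. Because compound 1, which also varies only at this saturated ring carbon, gives 3 nM, the group at this position appears tolerant to such exchange, and the step is expected to be small, a 2.0-fold higher number from compound 3 to compound 4 (0.30 log units; within the scatter), though a modest loss cannot be excluded given compound 2. Compound 4 is therefore estimated at 6 nM, within a range from 2 nM to 20 nM.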

Compound 4, half-maximal effective concentration: 10 nM
The estimate for compound 4 lay 1.7-fold (0.22 log units) below the measured number; the measured number falls inside the stated range.
By their numbers in this assay, from the lowest: compounds 1 and 3 (each within the scatter of the next); then compounds 4 and 2 (each within the scatter of the next).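

In this assay, the saturated ring carbon proves less tolerant than compounds 1 and 3 suggested: the new group gives a 3.3-fold higher number from compound 3 to compound 4 (0.52 log units; beyond the scatter) and also a 3.3-fold higher number from compound 1 to compound 4 (0.52 log units; beyond the scatter), both beyond the scatter. Set against the methyl(1,3-thiazol-2-yl)carbamoyl group, it gives a 1.8-fold lower number from compound 2 to compound 4 (0.26 log units; within the scatter), which stays within the scatter. Nothing measured here explains these steps. Going by these compounds, whether an amine or a carboxylic acid at this carbon would hold the number of compound 3 remains open, as does the effect of a longer chain.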